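The source may report more compounds than this note shows. Statements on the series, on what has been measured and on what is new or still open speak of the compounds shown alone.

Measured so far in a functional assay on A549 cells (Homo sapiens) for cytotoxicity, read by MTT assay, with a stated time of 72 h; on this read-out higher numbers stand for weaker inhibition and lower numbers for stronger inhibition:
compound 1 `Cc1cc(=O)n(-c2ccccc2C(F)(F)F)nc1C(=O)Nc1ccc(Oc2ncnc3ccsc23)c(F)c1` gives 4680 nM
compound 2 `Cc1cc(=O)n(-c2ccc(Br)cc2F)nc1C(=O)Nc1ccc(Oc2ncnc3ccsc23)c(F)c1` gives 2980 nM
compound 3 `Cc1cc(=O)n(-c2ccccc2OC(F)(F)F)nc1C(=O)Nc1ccc(Oc2ncnc3ccsc23)c(F)c1` gives 5720 nM

Compound 3 carries the highest of the three numbers in this assay, yet neither neighbour is separated from it by more than the scatter: a 1.2-fold higher number from compound 1 to compound 3 (0.09 log units; within the scatter) and a 1.9-fold higher number from compound 2 to compound 3 (0.28 log units; within the scatter). The three measured compounds share one core and differ only in the aryl group on the aromatic nitrogen, and every exchange of that aryl so far has stayed inside the scatter, including a 1.6-fold lower number from compound 1 to compound 2 (0.20 log units; within the scatter).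

Compound 4 `Cc1cc(=O)n(-c2cccc(F)c2)nc1C(=O)Nc1ccc(Oc2ncnc3ccsc23)c(F)c1` is the next member. Its change from compound 3: 3-fluorophenyl in place of 2-(trifluoromethoxy)phenyl on an aromatic nitrogen. This is again an exchange of the aryl on the aromatic nitrogen, of the same kind as the steps from compound 1 to compound 2 and from compound 2 to compound 3, each of which moved the number by no more than the scatter. Among the measured compounds shown here, nothing among the measured compounds distinguishes a singly fluorinated aryl from the others. The expectation is therefore a step of no size beyond the scatter in this assay: a 1.4-fold lower number from compound 3 to compound 4 (0.13 log units; within the scatter).

Compound 4 is accordingly estimated at 4200 nM, with a range of 1600 nM to 11000 nM.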

Compound 4, half-maximal inhibitory concentration: 5220 nM
The estimate for compound 4 lay 1.2-fold (0.09 log units) below the measured number; measured number inside the range.
By their numbers in this assay, from the lowest: compounds 2, 1, 4 and 3 (each within the scatter of the next).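

In this assay, 3-fluorophenyl (7 heavy atoms, 0 hydrogen-bond acceptors) in place of 2-(trifluoromethoxy)phenyl (11 heavy atoms, 1 hydrogen-bond acceptor) on the aromatic nitrogen gives a 1.1-fold lower number from compound 3 to compound 4 (0.04 log units; within the scatter), so at this position the aryl can lose that bulk and that acceptor with no step beyond the scatter. The singly fluorinated aryl is also not set apart from the two remaining aryls, with a 1.8-fold higher number from compound 2 to compound 4 (0.24 log units; within the scatter) and a 1.1-fold higher number from compound 1 to compound 4 (0.05 log units; within the scatter), which leaves all four aryls indistinguishable in this cytotoxicity read-out. No supporting data are available to explain why these exchanges leave the number within the scatter.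

Going by these compounds, all four groups on the aromatic nitrogen are fluorine-bearing phenyl rings, so it remains open whether a phenyl carrying an amine or a carboxylic acid, or a saturated cyclohexyl ring or a longer alkyl chain in place of the phenyl, would produce a step beyond the scatter. On these data alone, because only this one position varies, it also remains open whether the number would respond to a change elsewhere on the shared core, such as an ethyl group in place of the methyl group.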